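The source may hold more compounds than are shown below. What is called first, only, known or untested is meant among the compounds shown, and "the series" means these compounds.

Of the compounds shown here, three have so far been measured in an assay on BTI cells for inhibition of Amine oxidase [flavin-containing] B (Homo sapiens), read by fluorescence, with stated times of 30 min and 1 h; on this read-out higher numbers stand for weaker inhibition and lower numbers for stronger inhibition. Compound 1 `C#CCNC1CCc2c(OCCCCCN3CCN(c4cccc5c4ccn5Cc4cccc(Cl)c4)CC3)cccc21` gives 460 nM. Compound 2 `C#CCNC1CCc2c(OCCCCCN3CCN(c4cccc5c4ccn5S(=O)(=O)c4ccccc4)CC3)cccc21` gives 163 nM; it differs from compound 1 in one place, (phenylsulfonyl in place of 3-chlorobenzyl on an aromatic nitrogen), and that change made a 2.8-fold lower number from compound 1 to compound 2 (0.45 log units; beyond the scatter). Compound 3 `C#CCN(C)Cc1ccc(OCCCCCN2CCN(c3cccc4c3ccn4Cc3cccc(Cl)c3)CC2)cc1` gives 30 nM, the lowest of the three numbers; how its core differs from the core of compound 1 is not broken down here. Compound 4 `C#CCN(C)Cc1ccc(OCCCCCN2CCN(c3cccc4c3ccn4S(=O)(=O)c3ccccc3)CC2)cc1` has not yet been measured. It stands to compound 3 exactly as compound 2 stands to compound 1, carrying the same kind of change at the same place, (phenylsulfonyl in place of 3-chlorobenzyl on an aromatic nitrogen). Because the earlier step of a 2.8-fold lower number from compound 1 to compound 2 (0.45 log units; beyond the scatter) was modest yet beyond the scatter, a step of similar size is expected here, a 2.5-fold lower number from compound 3 to compound 4 (0.40 log units; beyond the scatter), with some allowance for the different core, since nothing shows that the change carries over unchanged. Compound 4 is therefore estimated at 12 nM, with a likely range from 4 nM to 35 nM.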

Compound 4, half-maximal inhibitory concentration: 154 nM
Beside the measured number, compound 4's estimate is 13-fold (1.11 log units) below it; measured number above the stated range.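

Replacing 3-chlorobenzyl with phenylsulfonyl on the aromatic nitrogen did not behave alike on the two cores in this assay: this time the change gave a 5.1-fold higher number from compound 3 to compound 4 (0.71 log units; beyond the scatter) and so ran in the opposite direction to the earlier step. Set side by side, the two steps differ by more than repeated measurements would explain: the same change on two cores in this assay, a 2.8-fold lower number (0.45 log units; beyond the scatter) from compound 1 to compound 2 and a 5.1-fold higher number (0.71 log units; beyond the scatter) from compound 3 to compound 4, 14-fold (1.16 log units) apart, beyond the scatter of two such steps. In this series, then, the effect of this change cannot simply be carried from one core to another, and even its direction depends on the core, but a single pair on each core does not show why this happens or how the change would behave on a third core.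

On these data alone, it remains open whether the same reversal appears with other groups on that nitrogen, such as a plain benzyl or a methanesulfonyl. As far as these compounds go, it is also open whether a longer chain between the two halves of the molecule would alter the outcome on either core.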